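Pyridin-4-yl for pyridin-3-yl: an expected cytotoxicity limit

The source may report more compounds than this note shows. Statements on the series, on what has been measured and on what is new or still open speak of the compounds shown alone.

Compound 1, `O=[N+]([O-])c1ccc(C2=NOC(c3ccc(N4CCN(Cc5ccccn5)CC4)cc3)C2)o1`, in an ADME assay on WI-38 cells (Homo sapiens) for cytotoxicity, read by MTT assay, with a stated time of 96 h (a higher number here means a weaker inhibitor, a lower number a stronger inhibitor), gives > 50000 nM, a limit of the assay rather than a number.
Compound 2, `O=[N+]([O-])c1ccc(C2=NOC(c3ccc(-c4cccnc4)cc3)C2)o1`, in this assay gives > 50000 nM, likewise a limit.
Compound 3, `O=[N+]([O-])c1ccc(C2=NOC(c3ccc(N4CCN(Cc5cccnc5)CC4)cc3)C2)o1`, in this assay gives > 50000 nM, again a limit.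

Compound 2 thus stands at the limit of > 50000 nM in this assay, at which 3 of the 3 values shown sit, where every measured value sits. Compound 4, `O=[N+]([O-])c1ccc(C2=NOC(c3ccc(-c4ccncc4)cc3)C2)o1`, differs from compound 2 by pyridin-4-yl in place of pyridin-3-yl on an aromatic carbon. Within the data shown here, the only step between measured compounds, a step that the two limits leave unreadable from compound 1 to compound 3, runs between two limits and gives no readable size; it also alters a different part of the shared core. Among the measured compounds shown here, no measured step therefore speaks to this change, and the expected step that the limit leaves unreadable from compound 2 to compound 4 is none beyond the scatter. Compound 4 is expected to give 60000 nM in this assay, with a range from 30000 nM to 200000 nM, most likely reported once more only as a limit.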

Compound 4, half-maximal inhibitory concentration: > 50000 nM
Compound 4: no number, only a limit (the forecaster's own chance of this, stated with the estimate: 85%); the middle value lies beyond the limit too.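

Compound 2 and compound 4 are both reported only as a limit, so no size can be read for this change: the limit of > 50000 nM in this assay, at which 4 of the 4 values shown sit.

The compounds shown leave open whether pyridin-4-yl and pyridin-3-yl differ at all in this assay.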